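The source may hold more compounds than are shown below. What is called first, only, known or untested is meant among the compounds shown, and "the series" means these compounds.

Measured so far:
Compound 1 `CC(=O)CN1C(=O)NC(C)(c2ccc(S(N)(=O)=O)cc2)C1=O` gives 0.54 in a physicochemical assay for lipophilicity, at pH 7.4; on this read-out lower numbers stand for lower lipophilicity and higher numbers for higher lipophilicity.
Compound 2 `CC1(c2ccc(S(N)(=O)=O)cc2)NC(=O)N(CC(=O)C2CC2)C1=O` gives 1.51 in this assay.

For the measured compounds named here, compound 2 holds the higher of the two numbers in this assay; the one measured step, a number 0.97 log units higher from compound 1 to compound 2 (beyond the scatter), separates it from compound 1. Compound 3 `CC1(c2ccc(S(N)(=O)=O)cc2)NC(=O)N(CC(=O)C2CCCCC2)C1=O` is not yet measured. It differs from compound 2 in one place: cyclohexyl in place of cyclopropyl on a carbonyl carbon. Going by the values given here, only the step from compound 1 to compound 2 bears on this change, as it too enlarges the group on that carbonyl carbon, and it was a modest rise beyond the scatter. With the carbonyl carbon now carrying cyclohexyl in place of cyclopropyl, a larger ring with more carbon atoms, the expected step in this assay is upward and somewhat larger than the measured one, a number 1.29 log units higher from compound 2 to compound 3 (beyond the scatter). Compound 3 is therefore expected to read about 2.8 in this assay, within a range from 2.3 to 3.3.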

Compound 3, distribution coefficient: 3.62
Compound 3: middle estimate off by 0.82 log units, on the low side, and the stated range ends below it.
By their numbers in this assay, from the lowest: compound 1; then compound 2; then compound 3.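

In this assay, the group on this carbonyl carbon can move the number much further than the earlier pair showed: the change from cyclopropyl to cyclohexyl gives a number 2.11 log units higher from compound 2 to compound 3 (beyond the scatter), a large step, where the change from methyl to cyclopropyl gave only the modest a number 0.97 log units higher from compound 1 to compound 2 (beyond the scatter). Taken together, replacing methyl with cyclohexyl gives a number 3.08 log units higher from compound 1 to compound 3 (beyond the scatter), also a large step. The number rises in the order methyl, cyclopropyl, cyclohexyl, and none of the three compounds goes against that order, but nothing available here accounts for the size of the latest step.

The compounds shown leave open whether the rise depends on the ring or on the carbon count, which an open-chain hexyl group on the same carbonyl carbon would help separate. They also leave open how the number would respond to a phenyl ring at this place, or to an amine or a hydroxyl group on the cyclohexyl ring.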